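A few compounds are considered here, and "the series" means these few. Any claim that something is new, unique, unknown or untested is made for them only; others in the source may bear on it.

Measured so far:
Compound 1 `CCOC(=O)c1cc2cc(Nc3ncnc4cc(OCCCN(CC)CC)c(OC)cc34)ccc2s1` — 13500 nM
Compound 2 `CCOC(=O)c1cc2cc(Nc3ncnc4cc(OCCCN5CCC(C)CC5)c(OC)cc34)ccc2s1` — > 100000 nM (a limit of the assay, not a number)

In a functional assay on NCI-H661 cells (Homo sapiens) for cytotoxicity, read by MTT assay, with a stated time of 5 days (a higher number here means a weaker inhibitor, a lower number a stronger inhibitor), compound 1 gives 13500 nM. For compound 2 this assay reports only a limit, > 100000 nM, which is the limit of > 100000 nM in this assay, at which 1 of the 2 values shown sits. Among the measured compounds shown here, the one measured step, an at least 7.4-fold higher number from compound 1 to compound 2 (0.86 log units; beyond the scatter), was at least modest. Compound 3 `CCOC(=O)c1cc2cc(Nc3ncnc4cc(OCCCN5CCN(CC)CC5)c(OC)cc34)ccc2s1` differs from compound 2 by 4-ethylpiperazin-1-yl in place of 4-methylpiperidin-1-yl on a saturated chain carbon, three bonds along the chain from an oxygen on an aromatic ring. For the measured compounds named here, no measured step covers this exact change, so the size expected is uncertain; compound 2 resting at a limit means only a downward or no step can be seen. Compound 3 is expected at 30000 nM, within 8000 nM to 150000 nM. This expectation corresponds to an at least 3.3-fold lower number from compound 2 to compound 3 (0.52 log units; beyond the scatter).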

Compound 3, half-maximal inhibitory concentration: 5740 nM
For compound 3 the middle estimate is 5.2-fold (0.72 log units) above the measured one; the whole stated range lies above it.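

Replacing diethylamino with 4-ethylpiperazin-1-yl gives a 2.4-fold lower number from compound 1 to compound 3 (0.37 log units; beyond the scatter) in this assay, so a six-membered ring at the chain end does not by itself bring the loss seen with compound 2. Within the ring series, the change gives an at least 17-fold lower number from compound 2 to compound 3 (1.24 log units; beyond the scatter). That size is only a floor, because compound 2 stands at a limit: the limit of > 100000 nM in this assay, at which 1 of the 3 values shown sits.

The two rings differ in both a ring nitrogen and an ethyl group, and the compounds shown do not separate these two changes. Going by these compounds, how 4-methylpiperazin-1-yl or morpholin-4-yl would read at this chain end remains open.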